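A few compounds are considered here, and "the series" means these few. Any claim that something is new, unique, unknown or untested is made for them only; others in the source may bear on it.

Compound 1, `O=C(Nc1ccccc1Cl)c1ccc(C(=O)O)nc1`: 16300 nM
Compound 2, `CCOc1ccccc1NC(=O)c1ccc(C(=O)O)nc1`: 32900 nM
Compound 3, `O=C(Nc1ccc(C(=O)O)nc1)c1ccc(Cl)cc1`: 22500 nM

All three compounds were tested in an assay on isolated protein (Gallus gallus) for inhibition of transmembrane prolyl 4-hydroxylase (Homo sapiens); on this read-out higher numbers stand for weaker inhibition and lower numbers for stronger inhibition. Compound 1 and compound 2 share a core and differ in one place: ethoxy in place of chloro on an aromatic carbon. This change gave a 2.0-fold higher number from compound 1 to compound 2 (0.31 log units; beyond the scatter). Compound 3 has the same atoms as compound 1 but joined differently; the difference between the two cores is not broken down here. In this assay compound 3 gives 22500 nM, which lies within the usual scatter of both compound 1 and compound 2, so no order among the three can be read from these numbers.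

Compound 4, `CCOc1ccc(C(=O)Nc2ccc(C(=O)O)nc2)cc1`, has not yet been measured. It differs from compound 3 by ethoxy in place of chloro on an aromatic carbon. Among the measured compounds shown here, this is the same kind of change as the one from compound 1 to compound 2, but not the same: there the ethoxy group is ortho to a large group, here it is para to a large group, and the cores differ as well. For the measured compounds named here, the expected step is a 1.8-fold higher number from compound 3 to compound 4 (0.25 log units; within the scatter), resting on the single earlier example, compound 1 to compound 2 with a 2.0-fold higher number from compound 1 to compound 2 (0.31 log units; beyond the scatter), and carrying extra uncertainty since only one such pair is available. For compound 4 the estimated value in this assay is 40000 nM, expected to fall between 18000 nM and 90000 nM.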

Compound 4, half-maximal inhibitory concentration: 11200 nM
Compound 4: middle estimate off by 3.6-fold (0.55 log units), on the high side; measured number below the stated range.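

In this assay, putting ethoxy in place of chloro gave a 2.0-fold lower number from compound 3 to compound 4 (0.30 log units; within the scatter), so this step on its own does not separate compound 4 from compound 3. The more useful result comes from setting it beside the earlier step, since the same swap of groups did not carry the same size or direction of step from one core to the other: the same change on two cores in this assay, a 2.0-fold higher number (0.31 log units; beyond the scatter) from compound 1 to compound 2 and a 2.0-fold lower number (0.30 log units; within the scatter) from compound 3 to compound 4, 4.1-fold (0.61 log units) apart, beyond the scatter of two such steps This shows that, in this series, a step measured on one core is a poor guide to the same change on another core, but it does not show what sets the two steps apart, since the pairs differ both in the core and in where the group sits on the ring, and each kind of pair is represented only once.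

The compounds shown leave open whether the place of the group or the core matters more, which would take chloro and ethoxy compared at a further place on the ring of either core. They also leave open how other groups would behave at the place para to a large group, such as methoxy, a longer chain like butoxy, or an amine, and whether any of these would give steps that agree across the two cores.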